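A Single Stereocentre in a Series Held at the Limit

The compounds below may be only part of what the source reports. "The series", "measured", "known", "first", "only" and "open" are said of these compounds alone.

In a functional assay on L1210 cells (Mus musculus) for antiproliferative activity, with a stated time of 72 h (a lower number here means that less compound is needed, a higher number that more compound is needed for the effect), compound 3 (`Cc1cn([C@@H]2O[C@H](CO)[C@@H](CO)[C@@H]2O)c(=O)[nH]c1=O`) gives > 100 uM as a limit and not a number. Compound 1 (`Cc1cn([C@@H]2O[C@H](CO)[C@@H](CF)[C@H]2O)c(=O)[nH]c1=O`) gives > 100 uM as a limit too. Compound 2 (`Cc1cn([C@@H]2O[C@H](CO)[C@@H](CN)[C@H]2O)c(=O)[nH]c1=O`) gives > 100 uM as a limit too. Compound 4 (`Cc1cn([C@@H]2O[C@H](CO)[C@@H](CO)[C@H]2O)c(=O)[nH]c1=O`) relates to compound 3 as follows (the two compounds have the same atoms and bonds and differ only in configuration as drawn: 1 of 4 stereo elements differ; a stereocentre at a saturated ring carbon is drawn S in compound 3 and R in compound 4). Among the compounds with values here, the only measured step is a step that the two limits leave unreadable from compound 1 to compound 2 and it offers no size to carry over. With the limit of > 100 uM in this assay, at which 3 of the 3 values shown sit, as the whole evidence on compound 3 , no step beyond the scatter is expected in this assay and no direction can be named. The expected change is a step that the limit leaves unreadable from compound 3 to compound 4 and it carries no weight as a direction. Compound 4 is estimated at 150 uM with a range from 60 uM to 400 uM and is expected to return a limit as well.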

Compound 4, concentration for half-maximal effect: > 100 uM
Compound 4: a limit, no number; the forecaster's own chance of this, stated with the estimate: 85%; the middle value is on the limit's open side.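

In this assay compound 4 gives > 100 uM, a limit and not a number. Within the data shown here, no step from compound 1, 2 or 3 to compound 4 can be read. The compounds shown leave open whether the configuration at that saturated ring carbon, or the choice of fluoro, amino or hydroxy, affects the antiproliferative activity at all.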